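The source may report more compounds than this note shows. Statements on the series, on what has been measured and on what is new or still open speak of the compounds shown alone.

Compound 1 `COc1ccc(C2CC(c3ccc(OC)c(OC)c3)=NN2C(=O)CO[N+](=O)[O-])c(OC)c1`: 58%
Compound 2 `COc1ccc(C2=NN(C(=O)CO[N+](=O)[O-])C(c3c(Cl)cccc3Cl)C2)cc1OC`: 58%
Compound 3 `COc1ccc(C2CC(c3ccc(OC)c(OC)c3)=NN2C(=O)C(C)O[N+](=O)[O-])c(OC)c1`: 56%

Three compounds of one series were tested in a functional assay on the whole organism (strain albino) for inhibition, with Rattus norvegicus as the target, read by paw edema, with stated times of 30 min and 3 h, at a dose of 100 mg/kg by the oral route; on this read-out higher numbers stand for more inhibition at the one dose given (going by the name of the read-out) and lower numbers for less inhibition. In this assay compound 1 gives 58%, compound 2 gives 58% and compound 3 gives 56%. The change 2,6-dichlorophenyl in place of 2,4-dimethoxyphenyl on a saturated ring carbon made the step of no change at the digits printed from compound 1 to compound 2 (within the scatter). The two cores differ by methyl in place of hydrogen on a saturated chain carbon bound to a carbonyl carbon and an oxygen on an unsaturated carbon, which made the step of a number 2 percentage points lower from compound 1 to compound 3 (within the scatter). Compound 4 `COc1ccc(C2=NN(C(=O)C(C)O[N+](=O)[O-])C(c3c(Cl)cccc3Cl)C2)cc1OC` has not been measured. It arises from compound 3 through (2,6-dichlorophenyl in place of 2,4-dimethoxyphenyl on a saturated ring carbon), the same kind of change as between compound 1 and compound 2, though here the place is next to the ring atom that bears a group of 8 heavy atoms rather than a ((nitrooxy)methyl)carbonyl group (7 heavy atoms). Because the earlier step was no change at the digits printed from compound 1 to compound 2 (within the scatter), the step from compound 3 to compound 4 is expected to be no change at the digits printed from compound 3 to compound 4 (within the scatter). Compound 4 is therefore estimated at 56%, between 46% and 66%.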

Compound 4, a percentage reported as inhibition, in the whole organism at one dose (the size of the read-out at that dose, not a potency): 55%
Compound 4: middle estimate off by 1 percentage points, on the high side; measured number inside the range.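

In this assay, 2,6-dichlorophenyl in place of 2,4-dimethoxyphenyl gave a number 1 percentage points lower from compound 3 to compound 4 (within the scatter), which agrees with the earlier step: the same change on two cores in this assay, no change at the digits printed (within the scatter) from compound 1 to compound 2 and a number 1 percentage points lower (within the scatter) from compound 3 to compound 4, 1 percentage points apart, within the scatter of two such steps Methyl in place of hydrogen on the chain gave a number 3 percentage points lower from compound 2 to compound 4 (within the scatter), and this too agrees with the earlier step: the same change on two cores in this assay, a number 2 percentage points lower (within the scatter) from compound 1 to compound 3 and a number 3 percentage points lower (within the scatter) from compound 2 to compound 4, 1 percentage points apart, within the scatter of two such steps Both changes therefore carried across the two cores in these four compounds, but every step stays within the scatter, so this shows only that the read-out stayed flat at the one dose, not that a change with a clear effect would carry over in the same way.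

As far as these compounds go, it remains open whether an amine or a carboxylic acid on the phenyl ring would shift the inhibition. The same is true of a longer chain in place of the methyl.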